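The source may report more compounds than this note shows. Statements on the series, on what has been measured and on what is new or still open speak of the compounds shown alone.

Three measured compounds set the scene. Compound 1 `Cc1nccc(N2CCc3nc(C4(C(=O)Nc5ccc(F)cc5)CCC4)ccc32)n1` gives 21 nM in an assay on HeLa cells for inhibition of Indoleamine 2,3-dioxygenase 1 (Homo sapiens); on this read-out higher numbers stand for weaker inhibition and lower numbers for stronger inhibition. Compound 2 `O=C(Nc1ccc(F)cc1)C1(c2ccc3c(n2)CCN3c2ccccn2)CCC1` gives 10.9 nM in this assay, and a 1.9-fold lower number from compound 1 to compound 2 (0.28 log units; within the scatter). Compound 3 `COC(=O)N1c2ccc(C3(NC(=O)c4ccc(F)cc4)CC3)cc2[C@@H]2CC[C@@H]21` gives 5.6 nM in this assay, the lowest of the three numbers; its gap to compound 2 is within the scatter, while its gap to compound 1 lies beyond it.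

Compound 4 `COC(=O)N1c2ccc(C3(NC(=O)c4ccc(F)cc4)CC3)cc2[C@H]2CC[C@H]21` is not yet measured. It differs from compound 3 as follows: the two compounds have the same atoms and bonds and differ only in configuration as drawn: 2 of 2 stereo elements differ (all stereocentres are inverted: mirror images); a stereocentre at a saturated ring carbon is drawn S in compound 3 and R in compound 4; a stereocentre at a saturated ring carbon is drawn S in compound 3 and R in compound 4. None of the measured steps bears on such a change: the only step shown, that from compound 1 to compound 2, swaps one group for another and says nothing about mirror images. Mirror images can give similar or very different numbers, and nothing here tells which. A somewhat weaker result is expected for compound 4, with wide uncertainty, so a 7.1-fold higher number from compound 3 to compound 4 (0.85 log units; beyond the scatter) is the estimated step. In this assay compound 4 is expected to give about 40 nM, most likely between 5 nM and 400 nM.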

Compound 4, half-maximal inhibitory concentration: 2.8 nM
Estimate against measurement, compound 4: 14-fold (1.15 log units) above, and the stated range ends above it.
By their numbers in this assay, from the lowest: compounds 4, 3, 2 and 1 (each within the scatter of the next, the first and the last beyond it).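

In this assay, inverting both stereocentres gives a 2.0-fold lower number from compound 3 to compound 4 (0.30 log units; within the scatter), so the two mirror images cannot be told apart on this read-out. Within the data shown here, the earlier compounds showed only one group swapped for another, whereas this pair shows that, at these two saturated ring carbons, either hand as drawn gives numbers that stay level. The comparison tests a single variable, and what makes it that clean is this: the fact that compounds 3 and 4 differ only in the configuration as drawn

Still open, as far as these compounds go, is whether inverting just one of the two stereocentres, rather than both, would leave the number equally undisturbed. Also open, from the compounds shown here alone, is whether the two mirror images would stay level with other groups on the shared core, such as a chlorine in place of the fluorine on the benzoyl group, or an ethyl group in place of the methyl of the ester.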